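This account rests on a few compounds, and the source may have more. Where it says the series, first, only, none or still open, it means among the compounds named here.

Measured compounds:
compound 1, `Cc1cc2c(cc1Cc1ccc(C(=O)NC[C@H]3CC[C@H](C(=O)O)CC3)o1)C(C)(C)CCC2(C)C`, 3000 nM in an assay on isolated protein for binding affinity to Gonadotropin-releasing hormone receptor (Rattus norvegicus); a lower number here means a stronger inhibitor, a higher number a weaker inhibitor
compound 2, `CCOC(=O)[C@H]1CC[C@H](CNC(=O)c2ccc(Cc3cc4c(cc3C)C(C)(C)CCC4(C)C)o2)CC1`, 2730 nM in this assay
compound 3, `Cc1ccc(CNC(=O)c2ccc(Cc3cc4c(cc3C)C(C)(C)CCC4(C)C)o2)cc1`, 60 nM in this assay

Compound 3 stands lowest of the three numbers in this assay; its nearest neighbour is compound 2, reached by a 46-fold lower number from compound 2 to compound 3 (1.66 log units; beyond the scatter), and the furthest is compound 1, reached by a 50-fold lower number from compound 1 to compound 3 (1.70 log units; beyond the scatter). Both steps replace the whole ring attached to the saturated chain carbon bound to the amide-type nitrogen, so they speak for the 4-methylphenyl as a group and not for any one part of it. The step of a 1.1-fold lower number from compound 1 to compound 2 (0.04 log units; within the scatter) adds an ethyl on the oxygen of the acid and changes nothing beyond the scatter.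

Compound 4, `Cc1cc2c(cc1Cc1ccc(C(=O)NCc3ccc(CN)cc3)o1)C(C)(C)CCC2(C)C`, keeps the 4-methylphenyl of compound 3 and differs from it only in amino in place of hydrogen on a saturated chain carbon bound to an aromatic carbon. Among the compounds with values here, no measured step bears directly on this change: none of the three steps adds a group on the saturated chain carbon bound to an aromatic carbon. Within the data shown here, the only hint is that compounds 1 and 2, which carry a hydrogen-bond donor or acceptor in place of the aryl ring, sit far above compound 3, but that is a different change in a different place. A step within the scatter, or a modest rise in the number, is therefore expected, so the step from compound 3 to compound 4 is estimated as a 2.5-fold higher number from compound 3 to compound 4 (0.40 log units; beyond the scatter). Compound 4 is expected to give about 150 nM in this assay, within a range of 40 nM to 600 nM.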

Compound 4, inhibition constant: 280 nM
Compound 4: the middle estimate sits 1.9-fold (0.27 log units) below what was measured, and the stated range covers the measured number.
By their numbers in this assay, from the lowest: compound 3; then compound 4; then compounds 2 and 1 (each within the scatter of the next).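

In this assay, amino in place of hydrogen on a saturated chain carbon bound to an aromatic carbon gives a 4.7-fold higher number from compound 3 to compound 4 (0.67 log units; beyond the scatter), the first sign that this position responds to a change and that this change raises the number. The aromatic ring keeps much of its advantage even with the amino group present: 4-(aminomethyl)phenyl in place of 4-(ethoxycarbonyl)cyclohexyl gives a 9.8-fold lower number from compound 2 to compound 4 (0.99 log units; beyond the scatter), and in place of 4-carboxycyclohexyl it gives an 11-fold lower number from compound 1 to compound 4 (1.03 log units; beyond the scatter), although both steps replace the whole group and cannot be assigned to any one part of it. Nothing available explains why the number rises with the amino group.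

The compounds shown leave open whether this rise belongs to the amine itself or would also follow another group on the same carbon, such as a hydroxyl or a methoxy. They also leave open how a longer chain ending in an amine, or a carboxylic acid in place of the aminomethyl on the phenyl ring, would read in this assay against the 4-methylphenyl of compound 3.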